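Inverting one stereocentre: compound 1 to compound 4

A few compounds are considered here, and "the series" means these few. Any claim that something is new, unique, unknown or untested is made for them only; others in the source may bear on it.

In an ADME assay on L1210 cells (Mus musculus) for cytotoxicity, with a stated time of 48 h (a higher number here means a weaker inhibitor, a lower number a stronger inhibitor), compound 1 (`CC1=CCC[C@](C)(CC/C(C)=C/CC2=C(O)C(=O)C=C(N[C@@H](C(=O)O)[C@@H](C)O)C2=O)[C@@H]1C`) gives > 10 ug/mL, which is a limit of the assay and not a number. Compound 2 (`C=C1[C@H](C)CCC[C@]1(C)CC/C(C)=C/CC1=C(O)C(=O)C=C(N[C@@H](C(=O)O)[C@@H](C)O)C1=O`) gives > 10 ug/mL, also a limit. Going by the values given here, compound 3 (`CC1=CCC[C@H]2[C@](C)(CC3=C(O)C(=O)C=C(N[C@@H](CO)C(=O)O)C3=O)[C@@H](C)CC[C@]12C`) gives 3.8 ug/mL, the only true number in the set. Compound 1 therefore sits at the limit of > 10 ug/mL in this assay, at which 2 of the 3 values shown sit.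

Compound 4 (`CC1=CCC[C@](C)(CC/C(C)=C/CC2=C(O)C(=O)C=C(N[C@@H](C(=O)O)[C@H](C)O)C2=O)[C@@H]1C`) keeps the atoms and bonds of compound 1: the two compounds have the same atoms and bonds and differ only in configuration as drawn: 1 of 5 stereo elements differ; a stereocentre at a saturated chain carbon is drawn R in compound 1 and S in compound 4. The stereocentre at a saturated chain carbon is drawn R in compound 1 and S in compound 4.

Among the compounds with values here, the only measured step, a step that the two limits leave unreadable from compound 1 to compound 2, concerns a different change and offers no size to carry over. Within the data shown here, no measured step tests this inversion, so no direction is expected in this assay. The expected step, a step that the limit leaves unreadable from compound 1 to compound 4, is estimated to stay within the scatter. Compound 4 is estimated at 14 ug/mL, with an expected range of 5 ug/mL to 40 ug/mL, and a report of only a limit is considered likely.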

Compound 4, half-maximal inhibitory concentration: > 10 ug/mL
Compound 4 ended at the assay's limit; the forecaster's own chance of this, stated with the estimate: 70%; the middle value lies beyond the limit too.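

Compound 1 and compound 4 both stand at a limit in this assay, not at a number, so no step between them can be read: the limit of > 10 ug/mL in this assay, at which 3 of the 4 values shown sit.

The compounds shown leave open whether the configuration at this saturated chain carbon matters for cytotoxicity at all.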